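Butyl to 3-methylphenyl on the ring nitrogen

The source may hold more compounds than are shown below. What is called first, only, known or untested is meant among the compounds shown, and "the series" means these compounds.

Measured in a functional assay on T47D cells (Homo sapiens) for antiproliferative activity, read by MTT assay, with a stated time of 72 h; a lower number here means a stronger inhibitor, a higher number a weaker inhibitor:
- compound 1 `CCCCn1ccnc1-c1cc(OC)c(OC)c(OC)c1`: > 100000 nM (a limit, not a number)
- compound 2 `COc1cc(-c2nccn2-c2ccc3[nH]ccc3c2)cc(OC)c1OC`: 2100 nM
- compound 3 `COc1cc(-c2nccn2-c2ccc3cc[nH]c3c2)cc(OC)c1OC`: 18000 nM

Compound 1 has no number, only (the limit of > 100000 nM in this assay, at which 1 of the 3 values shown sits). Its true position is therefore open, and any step from it can be judged only roughly.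

The next compound is compound 4 `COc1cc(-c2nccn2-c2cccc(C)c2)cc(OC)c1OC`, still unmeasured in this assay. The change is 3-methylphenyl in place of butyl on an aromatic nitrogen.

Among the measured compounds shown here, no measured pair differs in one place, so the expectation rests on the values alone. Compound 2 gives 2100 nM and carries no butyl on that nitrogen. Compound 3 gives 18000 nM and also carries no butyl there. A large step towards stronger inhibition is therefore expected, although compound 4 may also remain at the limit.

The expected change is an at least 6.6-fold lower number from compound 1 to compound 4 (0.82 log units; beyond the scatter). For compound 4 the estimated value is 15000 nM, with an expected range of 2500 nM to 90000 nM.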

Compound 4, half-maximal inhibitory concentration: 29300 nM
For compound 4 the middle estimate is 2.0-fold (0.29 log units) below the measured one, within the range that was stated.
By their numbers in this assay, from the lowest: compound 2; then compounds 3 and 4 (each within the scatter of the next). At a limit, above all of these: compound 1.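

Replacing butyl with 3-methylphenyl on the aromatic nitrogen in this assay gives an at least 3.4-fold lower number from compound 1 to compound 4 (0.53 log units; beyond the scatter). Among the compounds shown here, this is the first step that isolates this position, and it shows that a six-membered aromatic ring of carbon only, with 0 hydrogen-bond donors, can bring compound 4 to a measured 29300 nM. Compound 1 stands at a limit, so the size of the step can be given only as a bound: the limit of > 100000 nM in this assay, at which 1 of the 4 values shown sits.

The compounds shown leave open how much of the step belongs to the ring and how much to its methyl. Phenyl without the methyl, or benzyl on the same nitrogen, would separate the ring from its methyl and from its direct attachment to the nitrogen.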